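The source may report more compounds than this note shows. Statements on the series, on what has been measured and on what is new or still open speak of the compounds shown alone.

Measured so far:
Compound 1 `N=C(N)c1ccc(-c2ccc(-c3ccccc3)s2)cc1F` — 4180 nM
Compound 2 `COc1ccc(-c2ccc(-c3ccc(C(=N)N)cc3)s2)cc1` — 773 nM
Compound 3 `N=C(N)c1ccc(-c2ccc(-c3ccc(F)cc3)s2)cc1` — 1590 nM

These three compounds share a core and were tested in a functional assay on PC-3 cells (Homo sapiens) for inhibition, read by sulforhodamine B assay, with a stated time of 48 h; a lower number here means a stronger inhibitor of growth, a higher number a weaker inhibitor of growth. Among them compound 1 gives the highest number, and its gaps to compound 3 and to compound 2 both lie beyond the usual scatter. Compound 4 `N=C(N)c1ccc(-c2ccc(-c3ccc(Cl)cc3)s2)cc1F` has not yet been tested; it differs from compound 1 by chloro in place of hydrogen on an aromatic carbon, that is, on the outer ring of carbon only, at the position para to a large group.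

For the measured compounds named here, only one measured step touches that position: a 2.1-fold higher number from compound 2 to compound 3 (0.31 log units; beyond the scatter), which shows that exchanging one small group for another there shifts the number only modestly. Going by the values given here, no measured pair shows a hydrogen at that position turning into a halogen while all else is held fixed; compound 1 and compound 3 differ in two places, so their values can only be compared loosely, and on that loose view a substituent at that position sits with a lower number than none.

Taking that together, a modest lowering is expected: an estimated step of a 1.7-fold lower number from compound 1 to compound 4 (0.22 log units; within the scatter), so that compound 4 is expected to give about 2500 nM in this assay, within a range of 1000 nM to 6000 nM.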

Compound 4, concentration for 50% growth inhibition: 394 nM
The estimate for compound 4 lay 6.3-fold (0.80 log units) above the measured number, outside the stated range (below it).
By their numbers in this assay, from the lowest: compounds 4 and 2 (each within the scatter of the next); then compound 3; then compound 1.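

In this assay, for the compounds shown here, the change from phenyl to 4-chlorophenyl gives an 11-fold lower number from compound 1 to compound 4 (1.03 log units; beyond the scatter), so this position can move the number much more than the only earlier step there suggested, which was a 2.1-fold higher number from compound 2 to compound 3 (0.31 log units; beyond the scatter). Going by these compounds alone, this is the first pair in which a hydrogen at this position becomes a halogen with everything else held fixed, and it shows that adding one chlorine atom to the outer ring of carbon only is enough to produce a large gain in growth inhibition. Nothing available here explains why a single chlorine atom has an effect of this size.

Compound 3 and compound 4 differ in two places, so these compounds do not show whether fluoro and chloro at this position would give similar numbers on the same core, or whether chloro would give a step of this size in a compound without the fluoro on the ring that carries the amidine. From the compounds shown here alone, how a bromo group, an amine or a carboxylic acid would behave at this position also remains open.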